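Hydroxymethyl for Carboxy on a Pyrrolidine-Linked Hydroxamic Acid

The compounds below may be only part of what the source reports. "The series", "measured", "known", "first", "only" and "open" are said of these compounds alone.

Compound 1, `O=C(NO)c1cccc(-c2cn([C@H]3C[C@@H](CO)N(Cc4ccccc4)C3)nn2)c1`, in an assay on Sf9 cells for inhibition of histone deacetylase 11 (Homo sapiens), read by fluorescence, tested at 0.5 uM; on this read-out higher numbers stand for more inhibition at the one concentration tested (going by the name of the read-out) and lower numbers for less inhibition: < 10%, a limit of the assay rather than a number.
Compound 2, `O=C(NO)c1cccc(-c2cn([C@H]3C[C@@H](C(=O)O)N(Cc4ccccc4)C3)nn2)c1`, in this assay: 14%.
Compound 3, `O=C(NO)c1ccc(-c2cn([C@H]3C[C@H](C(=O)O)N(Cc4ccccc4)C3)nn2)cc1`, in this assay: < 10%, again a limit of the assay rather than a number.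

All three share a hydroxamic acid on a benzene ring, a triazole, and a five-membered saturated ring carrying a benzyl group; they differ in what sits on that saturated ring and in how the benzene ring is substituted. Compound 2 and compound 3 are built from the same atoms joined differently, and the difference between the two cores is not broken down here.

One change is seen once in measured form: hydroxymethyl in place of carboxy on a saturated ring carbon. It gave a number at least 4 percentage points lower from compound 2 to compound 1 (that floor lies within the scatter). The reading of compound 1 sits at the limit of < 10% in this assay, at which 2 of the 3 values shown sit.

The not yet measured compound 4, `O=C(NO)c1ccc(-c2cn([C@H]3C[C@H](CO)N(Cc4ccccc4)C3)nn2)cc1`, arises from compound 3 by the same change: hydroxymethyl in place of carboxy on a saturated ring carbon. The place is described in the same words in both cases, so this is the same change on the other core. Since compound 3 already sits at the limit, and the measured step ran downward, compound 4 is expected to remain at the limit as well. The expected step is a step that the limit leaves unreadable from compound 3 to compound 4, resting on a number at least 4 percentage points lower from compound 2 to compound 1 (that floor lies within the scatter). Compound 4 is thus estimated at 5%, between 0% and 12%.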

Compound 4, a percentage reported as inhibition, at one concentration (the size of the read-out at that concentration, not a potency): 16%
Estimate against measurement, compound 4: 11 percentage points below; the measured number lies above the stated range.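

On the core of compound 3, putting hydroxymethyl in place of carboxy on the saturated ring carbon gave, in this assay, a number at least 6 percentage points higher from compound 3 to compound 4 (that floor lies within the scatter). Set beside the earlier step, the two cores read as follows: the same change on two cores in this assay, a number at least 4 percentage points lower (that floor lies within the scatter) from compound 2 to compound 1 and a number at least 6 percentage points higher (that floor lies within the scatter) from compound 3 to compound 4; the limit leaves it open whether they differ. This shows that a downward step on one core was no safe guide to the other, since the same change here ended at a measured number rather than at the limit, but it does not show that the two cores truly respond in opposite ways, as each step has one end at a limit of the assay and a floor that lies within the scatter.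

The compounds shown leave open how this change behaves when both ends of a step are real numbers, and what the difference between the two cores contributes by itself. They also leave open what an amine or a longer chain would give in the same place on the saturated ring carbon, in place of carboxy or hydroxymethyl, in this assay.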